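Swapping the aryl group on a pyrazolone core: compound 4

The source may report more compounds than this note shows. Statements on the series, on what has been measured and on what is new or still open speak of the compounds shown alone.

Measured so far:
compound 1 `CCOC(=O)c1c(-c2ccc([N+](=O)[O-])cc2)n(-c2ccc(C(=O)NNC(=O)CO[N+](=O)[O-])cc2)[nH]c1=O` gives 22.2%
compound 2 `CCOC(=O)c1c(-c2ccccc2OC)n(-c2ccc(C(=O)NNC(=O)CO[N+](=O)[O-])cc2)[nH]c1=O` gives 25.1%
compound 3 `CCOC(=O)c1c(-c2ccccc2O)n(-c2ccc(C(=O)NNC(=O)CO[N+](=O)[O-])cc2)[nH]c1=O` gives 21.1%

These three compounds share a core and differ only in the aromatic ring attached to it. They were tested in a functional assay on the whole organism (strain Wistar) for inhibition, with Rattus norvegicus as the target, read by paw edema, with stated times of 3 h and 1 h, at a dose of 6 mg/kg by the oral route; on this read-out lower numbers stand for less inhibition and higher numbers for more inhibition at the one dose given (going by the name of the read-out). Compound 3 stands lowest of the three numbers, but its nearest neighbour is compound 1, with a step of a number 1.1 percentage points lower from compound 1 to compound 3 (within the scatter), and its furthest is compound 2, with a step of a number 4 percentage points lower from compound 2 to compound 3 (within the scatter); both are within the scatter, so no order among the three can be claimed.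

Compound 4 `CCOC(=O)c1c(-c2ccc(Cl)cc2)n(-c2ccc(C(=O)NNC(=O)CO[N+](=O)[O-])cc2)[nH]c1=O` is not yet measured. It differs from compound 3 by 4-chlorophenyl in place of 2-hydroxyphenyl on an aromatic carbon. Among the measured compounds shown here, the steps that bear on this change are the exchanges of the aromatic ring already seen: a number 2.9 percentage points higher from compound 1 to compound 2 (within the scatter), a number 1.1 percentage points lower from compound 1 to compound 3 (within the scatter) and a number 4 percentage points lower from compound 2 to compound 3 (within the scatter), each within the scatter. Because of a number 1.1 percentage points lower from compound 1 to compound 3 (within the scatter) and a number 4 percentage points lower from compound 2 to compound 3 (within the scatter), no step beyond the scatter is expected in this assay for compound 4. The expected step is a number 1.9 percentage points higher from compound 3 to compound 4 (within the scatter). For compound 4 the estimated value is 23%, between 14% and 32%.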

Compound 4, a percentage reported as inhibition, in the whole organism at one dose (the size of the read-out at that dose, not a potency): 6.43%
Estimate against measurement, compound 4: 16.6 percentage points above; measured number below the stated range.
By their numbers in this assay, from the lowest: compound 4; then compounds 3, 1 and 2 (each within the scatter of the next).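

In this assay, this position on the shared core proved sensitive to the choice of aryl group. The three earlier rings could not be told apart, yet 4-chlorophenyl stands apart from each of them, with a number 14.7 percentage points lower from compound 3 to compound 4 (beyond the scatter), a number 18.7 percentage points lower from compound 2 to compound 4 (beyond the scatter) and a number 15.8 percentage points lower from compound 1 to compound 4 (beyond the scatter); the last of these steps shows that exchanging only nitro for chloro on the ring is enough to move the number beyond the scatter. Nothing measured here accounts for this drop.

The compounds shown leave open whether the low number is specific to chloro, which a ring bearing fluoro, bromo or an amine, or a plain phenyl ring, could help to settle. They also leave open whether the same exchange would have a similar effect with a carboxylic acid in place of the ethoxycarbonyl group.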